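The compounds below may be only part of what the source reports. "The series", "measured", "known", "first", "only" and "open" are said of these compounds alone.

Working notes on a short series built on one shared core. Going by the values given here, compound 1 `COc1cc(Cc2nc3c(N)ncnc3n2CCO)cc(OC)c1OC` is the first member; in a functional assay on MCF7 cells (Homo sapiens) for cytotoxicity (on this read-out higher numbers stand for an effect only at larger amounts of compound and lower numbers for an effect already at smaller amounts), compound 1 gives 222000000 nM. Compound 2 `COc1cc(Cc2nc3c(N)ncnc3n2CCCO)cc(OC)c1OC` differs from it by a single change, and the step of a 2.4-fold lower number from compound 1 to compound 2 (0.38 log units; beyond the scatter) was modest but beyond the scatter. In this assay, among the compounds with values here, compound 2 gives 92700000 nM, the lowest of the two numbers so far. Compound 3 `COc1cc(Cc2nc3c(N)ncnc3n2CCCCO)cc(OC)c1OC` is the next member, not yet measured. Its change from compound 2 is hydroxymethyl in place of hydroxy on a saturated chain carbon, three bonds along the chain from an aromatic nitrogen. Within the data shown here, the only measured step bearing on this is a 2.4-fold lower number from compound 1 to compound 2 (0.38 log units; beyond the scatter), the same kind of change on the shorter chain. A further lowering of similar or smaller size is therefore expected, a 1.9-fold lower number from compound 2 to compound 3 (0.27 log units; within the scatter). For compound 3 the estimate in this assay is 50000000 nM, with a range from 20000000 nM to 150000000 nM.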

Compound 3, half-maximal effective concentration: 76900000 nM
Estimate against measurement, compound 3: 1.5-fold (0.19 log units) below; the range from low to high includes it.
By their numbers in this assay, from the lowest: compounds 3 and 2 (each within the scatter of the next); then compound 1.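

In this assay, the further extension to 4-hydroxybutyl gives a 1.2-fold lower number from compound 2 to compound 3 (0.08 log units; within the scatter) and so, unlike the first extension, does not separate the two neighbouring chain lengths: 3-hydroxypropyl and 4-hydroxybutyl read alike here. Across the whole span from the shortest chain to the longest there is a 2.9-fold lower number from compound 1 to compound 3 (0.46 log units; beyond the scatter) and this remains a modest change, so among the three compounds only 2-hydroxyethyl stands apart from the other two chains. Nothing available bears on why the numbers fall this way.

Still open, on these data alone, is whether a longer chain than 4-hydroxybutyl would stay level with compound 3 or move away from it. Also open is whether an amine or a carboxylic acid in place of the terminal hydroxy would shift the number at all, since every compound shown ends in hydroxy.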